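The source may report more compounds than this note shows. Statements on the series, on what has been measured and on what is new or still open speak of the compounds shown alone.

Three compounds of the series share one core and differ only in the aryl group on an amine nitrogen in a ring: compound 1 `Nc1scc(CN2CCN(c3cc(Cl)cc(Cl)c3)CC2)c1C(=O)c1ccc(Cl)cc1`, compound 2 `Nc1scc(CN2CCN(c3ccc([N+](=O)[O-])cc3)CC2)c1C(=O)c1ccc(Cl)cc1` and compound 3 `Nc1scc(CN2CCN(c3c(F)cccc3F)CC2)c1C(=O)c1ccc(Cl)cc1`. In an assay on CHO cells for displacement of a labelled ligand from adenosine receptor A1 (Homo sapiens), read by scintillation counting, with a stated time of 120 min, tested at 10 uM (a higher number here means more inhibition at the concentration tested (going by the name of the read-out), a lower number less inhibition), compound 1 gives 1%, compound 2 gives 1% and compound 3 gives 1%. Compound 2 thus stands level with both neighbours: the steps of no change at the digits printed from compound 1 to compound 2 (within the scatter), no change at the digits printed from compound 1 to compound 3 (within the scatter) and no change at the digits printed from compound 2 to compound 3 (within the scatter) all lie within the scatter, so none of the three aryl exchanges shifts the read-out.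

Compound 4 `Nc1scc(CN2CCN(c3ccccc3Cl)CC2)c1C(=O)c1ccc(Cl)cc1` remains to be tested in this assay. Relative to compound 2 the change is 2-chlorophenyl in place of 4-nitrophenyl on an amine nitrogen in a ring. All three measured steps bear on this change, since each swaps one aryl group for another at the same ring nitrogen, and none of them moved the read-out beyond the scatter. The expected step in this assay is accordingly no change at the digits printed from compound 2 to compound 4 (within the scatter), no movement beyond the scatter. Compound 4 is estimated in this assay at 1%, with a range from 0% to 10%.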

Compound 4, a percentage reported as inhibition, at one concentration (the size of the read-out at that concentration, not a potency): 2%
Estimate against measurement, compound 4: 1 percentage points below, within the range that was stated.
By their numbers in this assay, from the lowest: compounds 1, 2, 3 and 4 (each within the scatter of the next).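

In this assay the 2-chlorophenyl group on the amine nitrogen in a ring joins the other aryl groups without leaving the scatter: a number 1 percentage points higher from compound 2 to compound 4 (within the scatter), a number 1 percentage points higher from compound 3 to compound 4 (within the scatter) and a number 1 percentage points higher from compound 1 to compound 4 (within the scatter). The flat read-out at this position therefore extends to an aryl group with a single chlorine, alongside the 3,5-dichlorophenyl, 2,6-difluorophenyl and 4-nitrophenyl groups. No supporting measurement accounts for this flat result.

All four compounds are read at one concentration and none stands apart from the others, so no group at this nitrogen is yet known to shift the read-out beyond the scatter. On these data alone, whether a phenyl ring bearing a carboxylic acid or an amine, or a longer alkyl chain in place of the aryl group, would do so remains open.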